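Thiophen-2-yl for 1H-pyrrol-2-yl: expectation for compound 4

This account rests on a few compounds, and the source may have more. Where it says the series, first, only, none or still open, it means among the compounds named here.

Compound 3 `CC1=CC[C@H](C(C)(C)NC(=S)N/N=C/c2ccc[nH]2)CC1` gives 33500 nM in a functional assay on OVCAR-3 cells (Homo sapiens) for inhibition, read by sulforhodamine B assay, with a stated time of 48 h (a lower number here means a stronger inhibitor of growth, a higher number a weaker inhibitor of growth), the highest of the three numbers: compound 2 `CC1=CC[C@H](C(C)(C)NC(=S)N/N=C/c2ccco2)CC1` gives 10800 nM and compound 1 `CC1=CC[C@H](C(C)(C)NC(=S)N/N=C/c2ccccc2O)CC1` gives 5500 nM. The steps of a 3.1-fold higher number from compound 2 to compound 3 (0.49 log units; beyond the scatter) and a 6.1-fold higher number from compound 1 to compound 3 (0.78 log units; beyond the scatter) both run towards higher numbers at compound 3, while a 2.0-fold higher number from compound 1 to compound 2 (0.29 log units; within the scatter) stays within the scatter. Compound 4 `CC1=CC[C@H](C(C)(C)NC(=S)N/N=C/c2cccs2)CC1` differs from compound 3 by thiophen-2-yl in place of 1H-pyrrol-2-yl on a carbon with a double bond to nitrogen. The step that bears most on this is a 3.1-fold higher number from compound 2 to compound 3 (0.49 log units; beyond the scatter), an exchange between two five-membered rings with one hetero atom each; moving back to a ring with 1 hydrogen-bond acceptor and no donor is expected to give a modestly lower number in this assay, about a 3.0-fold lower number from compound 3 to compound 4 (0.48 log units; beyond the scatter). Compound 4 is therefore estimated at 11000 nM, with a range of 4000 nM to 30000 nM.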

Compound 4, concentration for 50% growth inhibition: 13100 nM
Compound 4: middle estimate off by 1.2-fold (0.08 log units), on the low side, within the range that was stated.
By their numbers in this assay, from the lowest: compounds 1, 2 and 4 (each within the scatter of the next, the first and the last beyond it); then compound 3.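

In this assay, thiophen-2-yl on a carbon with a double bond to nitrogen gives a 2.6-fold lower number from compound 3 to compound 4 (0.41 log units; beyond the scatter), while a 1.2-fold higher number from compound 2 to compound 4 (0.08 log units; within the scatter) stays within the scatter. Among the three five-membered rings, 1H-pyrrol-2-yl, the one with a hydrogen-bond donor, therefore stands alone at the highest number. The 2-hydroxyphenyl group now separates from a five-membered ring beyond the scatter, with a 2.4-fold higher number from compound 1 to compound 4 (0.38 log units; beyond the scatter).

No supporting data bear on the reason for these differences. On these data alone, whether an unsubstituted phenyl or a pyridin-2-yl ring at this carbon would match 2-hydroxyphenyl remains open.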